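The compounds below may be only part of what the source reports. "The series", "measured", "known", "first", "only" and "open" are said of these compounds alone.

Within the data shown here, in a functional assay on MCF7 cells (Homo sapiens) (a lower number here means a stronger inhibitor of growth, a higher number a weaker inhibitor of growth), compound 1 (`O=S(=O)(/C=C/c1ccc(Br)cc1)Cc1ccc(Nc2ncnc3ccccc23)cc1`) gives 91000 nM, the only actual number available so far. Compound 2 (`O=S(=O)(/C=C/c1ccc(F)cc1F)Cc1ccc(Nc2ncnc3ccccc23)cc1`) reads > 100000 nM, which is a limit of the assay and not a number. Among the measured compounds shown here, the single measured step, 2,4-difluorophenyl in place of 4-bromophenyl, is an at least 1.0-fold higher number from compound 1 to compound 2 (0.04 log units; that floor lies within the scatter). As far as these compounds go, it shows no change beyond the scatter, although its true size stays open. Compound 3 (`O=S(=O)(/C=C/c1ccc(O)cc1)Cc1ccc(Nc2ncnc3ccccc23)cc1`) carries hydroxy in place of bromo on an aromatic carbon, para to a large group: hydroxy in place of bromo on an aromatic carbon. For the measured compounds named here, no measured step involves a hydroxy group, so the only guides are compound 1 at 91000 nM and the step to compound 2, which changes the same substituted phenyl group. On that thin basis, no shift beyond the scatter is expected in this assay, in either direction. The estimated step is a 1.3-fold lower number from compound 1 to compound 3 (0.11 log units; within the scatter), and a real change of either sign remains possible. For compound 3 the expected value is 70000 nM, with an estimated range from 20000 nM to 100000 nM.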

Compound 3, concentration for 50% growth inhibition: 100000 nM
Compound 3: the middle estimate sits 1.4-fold (0.15 log units) below what was measured; measured number inside the range.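

In this assay, putting hydroxy in place of bromo on an aromatic carbon, para to a large group, gives a 1.1-fold higher number from compound 1 to compound 3 (0.04 log units; within the scatter). Unlike the earlier step to the 2,4-difluorophenyl group, whose true size stayed open, this is a step of readable size, and it shows that a group with one hydrogen-bond donor and one hydrogen-bond acceptor can replace bromo at this position with no change beyond the scatter. Putting 4-hydroxyphenyl in place of 2,4-difluorophenyl gives a number no higher from compound 2 to compound 3 (the limit leaves the size open). The size of this step cannot be read, because compound 2 carries a limit of the assay and not a number: the limit of > 100000 nM in this assay, at which 1 of the 3 values shown sits.

The compounds shown leave open whether any group on this aromatic carbon moves the number beyond the scatter, since bromo and hydroxy give values within the scatter of each other. An amine, a carboxylic acid or a methoxy group at this position could answer that, as could a longer chain in place of the 2-(4-hydroxyphenyl)ethenyl group.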